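This account rests on a few compounds, and the source may have more. Where it says the series, first, only, none or still open, it means among the compounds named here.

Of the compounds shown here, two have numbers so far. In a functional assay on KB 3-1 cells (Homo sapiens) for cytotoxicity, read by MTT assay, with a stated time of 72 h (on this read-out higher numbers stand for weaker inhibition and lower numbers for stronger inhibition), compound 1 `CN(C)c1ccc(NC(=S)N/N=C2\C(=O)Nc3ccccc32)cc1` gives 6950 nM, and compound 2 `Cc1ccc(NC(=S)N/N=C2\C(=O)Nc3ccccc32)cc1C` gives 4370 nM in this assay; these two values lie within the scatter of each other, so compound 1 stands level with compound 2 on the numbers shown. Compound 3 `CCCC1CCC(c2ccc(NC(=S)N/N=C3\C(=O)Nc4ccccc43)cc2)CC1` has not been measured. It differs from compound 1 by 4-propylcyclohexyl in place of dimethylamino on an aromatic carbon. Going by the values given here, no measured pair shows a change of this kind, so the size of the step rests on expectation alone: a moderate move toward a lower number in this assay is expected, though no step beyond the scatter remains possible. For compound 3 the expected value in this assay is 3500 nM, in the range 1200 nM to 10000 nM. This estimate means a step of a 2.0-fold lower number from compound 1 to compound 3 (0.30 log units; within the scatter).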

Compound 3, half-maximal inhibitory concentration: 17500 nM
Compound 3: middle estimate off by 5.0-fold (0.70 log units), on the low side; the measured number lies above the stated range.
By their numbers in this assay, from the lowest: compounds 2 and 1 (each within the scatter of the next); then compound 3.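

In this assay, going by these compounds alone, 4-propylcyclohexyl in place of dimethylamino on this aromatic carbon gives a 2.5-fold higher number from compound 1 to compound 3 (0.40 log units; beyond the scatter), the only step so far that lies beyond the scatter. This position therefore responds to the change of group, and here a group of carbon only, with a non-aromatic ring, moves the number upward. No measurement at hand explains this step.

On these data alone, it remains open whether the propyl chain, the cyclohexyl ring or the loss of dimethylamino sets the change. A plain cyclohexyl, a propyl chain alone or a morpholine on the same carbon would separate these.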